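A few compounds are considered here, and "the series" means these few. Any claim that something is new, unique, unknown or untested is made for them only; others in the source may bear on it.

Working notes on the series, values from a physicochemical assay for solubility, read by HPLC, using the shake flask method, in phosphate buffer, measured as kinetic solubility, with a stated time of 20 h, at pH 6.5; on this read-out higher numbers stand for higher solubility and lower numbers for lower solubility

- compound 1 `CC(C)(C)N1CCN(c2ccc(Nc3nc4cnc(Nc5cccc(C(F)(F)F)c5)cc4[nH]3)nc2)CC1` gives 50000 nM
- compound 2 `FC(F)(F)c1cccc(Nc2cc3[nH]c(Nc4ccc(N5CCN(CC6CC6)CC5)cn4)nc3cn2)c1` gives 130000 nM
- compound 3 `C[C@H]1CN(c2ccc(Nc3nc4cnc(Nc5cccc(C(F)(F)F)c5)cc4[nH]3)nc2)CCN1` gives 180000 nM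
- compound 4 `Fc1ccc(Nc2cc3[nH]c(Nc4ccc(N5CCN(CC6CC6)CC5)cn4)nc3cn2)cc1F` has not yet been measured

Compound 2 stands with compound 3 at the upper end of this small set, with a 1.4-fold higher number from compound 2 to compound 3 (0.14 log units; within the scatter). Compound 1 stands apart, with a 2.6-fold higher number from compound 1 to compound 2 (0.41 log units; beyond the scatter) and a 3.6-fold higher number from compound 1 to compound 3 (0.56 log units; beyond the scatter).

Compound 4 keeps the 4-(cyclopropylmethyl)piperazin-1-yl group of compound 2 and differs elsewhere: 3,4-difluorophenyl in place of 3-(trifluoromethyl)phenyl on a nitrogen on an aromatic ring. For the measured compounds named here, no measured step touches the 3-(trifluoromethyl)phenyl group, since all three change only the piperazine substituent. They bear on this change only indirectly, by showing how far one change has moved the number in this series, and the largest is a 3.6-fold higher number from compound 1 to compound 3 (0.56 log units; beyond the scatter). With no direct evidence, no shift beyond the scatter is expected, and the estimated step is a 1.2-fold higher number from compound 2 to compound 4 (0.06 log units; within the scatter). The estimate for compound 4 is 150000 nM, with an expected range from 60000 nM to 350000 nM.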

Compound 4, solubility: 10000 nM
The estimate for compound 4 lay 15-fold (1.18 log units) above the measured number, and the stated range ends above it.
By their numbers in this assay, from the lowest: compound 4; then compound 1; then compounds 2 and 3 (each within the scatter of the next).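

In this assay, the group on the nitrogen on an aromatic ring turns out to be a sensitive position: 3,4-difluorophenyl in place of 3-(trifluoromethyl)phenyl gives a 13-fold lower number from compound 2 to compound 4 (1.11 log units; beyond the scatter), a step printed as large, while the steps among compounds 1, 2 and 3 at the piperazine are modest or within the scatter. The change is small by count, with 10 heavy atoms leaving and 8 entering, and neither group carries hydrogen-bond donors, hydrogen-bond acceptors or a net charge, so these counts do not separate the two groups. No measurement at hand explains the size of this step.

From the compounds shown here alone, this position rests on a single pair, both members carrying 4-(cyclopropylmethyl)piperazin-1-yl, so whether the step holds with other piperazine groups remains open. Going by these compounds, how a phenyl bearing an amine or a carboxylic acid would read at this place also remains open.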